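Returning a Hydroxyphenyl Group to the Shared Core

The compounds below may be only part of what the source reports. "The series", "measured", "known", "first", "only" and "open" are said of these compounds alone.

Of the compounds shown here, two built on one shared core have been tested in an assay on cells for displacement of a labelled ligand from adenosine receptor A2b (Homo sapiens), read by scintillation counting and radioligand binding, with a stated time of 30 min, tested at 10 uM; on this read-out lower numbers stand for less inhibition and higher numbers for more inhibition at the one concentration tested (going by the name of the read-out). Compound 1 `CN1CCN(c2nc(-c3cccc(O)c3)nc3c2ncn3C)CC1` carries a 3-hydroxyphenyl group and gives 47.8% in this assay. Compound 2 `CN1CCN(c2nc(-c3ccc(Cl)c(Cl)c3)nc3c2ncn3C)CC1` carries a 3,4-dichlorophenyl group in its place and gives 28.3%. Within the data shown here, the single measured step, a number 19.5 percentage points lower from compound 1 to compound 2 (beyond the scatter), shows that exchanging the hydroxyphenyl for the dichlorophenyl lowered the read-out by a modest but real amount. Among the measured compounds shown here, compound 2 therefore stands lowest of the two numbers, with compound 1 as its only neighbour, and that gap lies beyond the scatter.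

Compound 3 `CN1CCN(c2nc(-c3ccccc3O)nc3c2ncn3C)CC1` has not yet been measured. It differs from compound 2 in one place: 2-hydroxyphenyl in place of 3,4-dichlorophenyl on an aromatic carbon. For the measured compounds named here, the one measured step bears on this change only in part, since it involved a 3-hydroxyphenyl rather than a 2-hydroxyphenyl group. Because a number 19.5 percentage points lower from compound 1 to compound 2 (beyond the scatter) fell when a hydroxyphenyl left, a rise of similar or somewhat smaller size is expected when a hydroxyphenyl returns, and a step of a number 13.7 percentage points higher from compound 2 to compound 3 (beyond the scatter) is expected. Compound 3 is estimated to give about 42% in this assay, within a range of 22% to 62%.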

Compound 3, a percentage reported as inhibition, at one concentration (the size of the read-out at that concentration, not a potency): 36%
For compound 3 the middle estimate is 6 percentage points above the measured one, within the range that was stated.
By their numbers in this assay, from the lowest: compounds 2 and 3 (each within the scatter of the next); then compound 1.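

In this assay, exchanging 3,4-dichlorophenyl for 2-hydroxyphenyl on this aromatic carbon, which lies between two ring nitrogen atoms, gives a number 7.7 percentage points higher from compound 2 to compound 3 (within the scatter), so carrying a hydroxyphenyl group here does not by itself set compound 3 apart from compound 2. The comparison of the two hydroxyphenyl groups gives a number 11.8 percentage points lower from compound 1 to compound 3 (beyond the scatter), which shows that the place of the hydroxyl on the phenyl ring counts in this read-out, with the 3-hydroxyphenyl group of compound 1 giving the higher number. Nothing available explains why these two hydroxyphenyl groups differ.

The compounds shown leave open whether an amine or a carboxylic acid in place of the hydroxyl on the phenyl ring would match compound 1 or fall closer to compound 2. On these data alone, all three compounds also keep the same 4-methylpiperazin-1-yl group and were read at one concentration only, so the effect of a longer chain in place of its methyl, and how these differences would appear at other concentrations, remain unknown.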